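Adding Fluoro to Compound 3: An Expected Growth Inhibition Shift

A few compounds are considered here, and "the series" means these few. Any claim that something is new, unique, unknown or untested is made for them only; others in the source may bear on it.

Of the compounds shown here, three have so far been measured in a functional assay on MCF7 cells (Homo sapiens) for cytotoxicity, read by MTT assay, with a stated time of 72 h, tested at 1 uM; a lower number here means less inhibition of growth, a higher number more inhibition of growth at the concentration tested. Compound 1 `N/C(=N\NC(=S)N1CCOCC1)c1ccccn1` gives 14.7%, compound 2 `N/C(=N\NC(=S)N1CCCC1)c1ccc(F)cn1` gives 51%, and compound 3 `N/C(=N\NC(=S)N1CCSCC1)c1ccccn1` gives 16.3%. Compound 3 thus holds the second highest of the three numbers; its nearest neighbour is reached by the step of a number 1.6 percentage points higher from compound 1 to compound 3 (within the scatter), which lies within the scatter, while compound 2 stands furthest away, beyond the scatter. Compound 4 `N/C(=N\NC(=S)N1CCSCC1)c1ccc(F)cn1` differs from compound 3 by fluoro in place of hydrogen on an aromatic carbon. Among the compounds with values here, no measured step alters this one place alone. Within the data shown here, the single measured step, from compound 1 to compound 3, exchanges the amine on the thiocarbonyl carbon and stayed within the scatter. Compound 2 carries the same fluoro but a different amine, so its value and that of compound 1 show only what two changes together do. Because compound 2 gives 51% with fluoro present, some rise is anticipated, though its size is uncertain. Compound 4 is expected to give 35%, between 15% and 55%. The expected step is a number 18.7 percentage points higher from compound 3 to compound 4 (beyond the scatter).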

Compound 4, percent growth inhibition at one concentration: 30.6%
The estimate for compound 4 lay 4.4 percentage points above the measured number, and the stated range covers the measured number.
By their numbers in this assay, from the lowest: compounds 1 and 3 (each within the scatter of the next); then compound 4; then compound 2.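

In this assay the change of hydrogen to fluoro on an aromatic carbon, two atoms from the ring nitrogen, can now be read alone, as a number 14.3 percentage points higher from compound 3 to compound 4 (beyond the scatter) and with the amine held constant. Earlier, fluoro had appeared only together with a different amine. The amine also proves to count when fluoro is present, giving a number 20.4 percentage points lower from compound 2 to compound 4 (beyond the scatter) even though the exchange of morpholin-4-yl for thiomorpholin-4-yl without fluoro stayed within the scatter. Nothing available explains either step.

The compounds shown leave open whether chloro or a methoxy group at this place would give a similar step. They also leave open whether fluoro at this place would raise the number on the morpholin-4-yl or pyrrolidin-1-yl compounds by a similar amount.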